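The source may hold more compounds than are shown below. What is called first, only, known or untested is meant among the compounds shown, and "the series" means these compounds.

Going by the values given here, compound 2 `CCCN1CCN(CCCCn2c3c(c4ccccc42)C(=O)c2c[n+]([O-])c4ccccc4c2C3=O)CC1` is measured in a functional assay on SH-SY5Y cells (Homo sapiens) for cytotoxicity, read by MTT assay, with a stated time of 72 h (on this read-out higher numbers stand for weaker inhibition and lower numbers for stronger inhibition), where compound 2 gives 3970 nM; this is the higher of the two numbers so far, the other being compound 1 `CN1CCN(CCCCCn2c3c(c4ccccc42)C(=O)c2c[n+]([O-])c4ccccc4c2C3=O)CC1`, which in this assay gives 830 nM. Among the compounds with values here, that one step, a 4.8-fold higher number from compound 1 to compound 2 (0.68 log units; beyond the scatter), is the only comparison available. Compound 3 `O=C1c2c[n+]([O-])c3ccccc3c2C(=O)c2c1c1ccccc1n2CCCN1CCC(O)CC1` differs from compound 2 by 4-hydroxypiperidin-1-yl in place of (4-propylpiperazin-1-yl)methyl on a saturated chain carbon, three bonds along the chain from an aromatic nitrogen. Within the data shown here, no measured step covers this change, so no direction can be drawn from the data, and a step of a 1.1-fold lower number from compound 2 to compound 3 (0.05 log units; within the scatter) is expected, within the scatter. Compound 3 is thus expected to give about 3500 nM, somewhere between 900 nM and 13000 nM.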

Compound 3, half-maximal inhibitory concentration: 130 nM
The estimate for compound 3 lay 27-fold (1.43 log units) above the measured number, outside the stated range (below it).
By their numbers in this assay, from the lowest: compound 3; then compound 1; then compound 2.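

The group at the end of the chain is far from a silent passenger: 4-hydroxypiperidin-1-yl in place of (4-propylpiperazin-1-yl)methyl, three bonds along the chain from an aromatic nitrogen, gives a 31-fold lower number from compound 2 to compound 3 (1.48 log units; beyond the scatter) and stronger inhibition. Measured against the other piperazine, in place of 2-(4-methylpiperazin-1-yl)ethyl, it gives a 6.4-fold lower number from compound 1 to compound 3 (0.81 log units; beyond the scatter) in the same direction. No measurement at hand explains this gain.

Each step changes the ring and the chain together, so their shares stay unseparated. Plain piperidin-1-yl on the same chain, or 4-hydroxypiperidin-1-yl on a longer chain, would help to tell them apart.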